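This account rests on a few compounds, and the source may have more. Where it says the series, first, only, none or still open, it means among the compounds named here.

Compound 1 `CC(=O)Nc1ccn([C@@H]2CO[C@H](CO)O2)c(=O)n1` gives 6870 nM in a functional assay on A549 cells (Homo sapiens) for cytotoxicity, read by sulforhodamine B assay, with a stated time of 72 h; a higher number here means a weaker inhibitor, a lower number a stronger inhibitor; compound 2 `CCCCC(=O)Nc1ccn([C@@H]2CO[C@H](CO)O2)c(=O)n1` gives 5230 nM in this assay.

Compound 2 carries the smaller of the two numbers shown, but the gap to compound 1 is within the scatter, as the step of a 1.3-fold lower number from compound 1 to compound 2 (0.12 log units; within the scatter) shows. Compound 3 `COc1ccc(C(=O)Nc2ccn([C@@H]3CO[C@H](CO)O3)c(=O)n2)cc1` has not yet been measured; it differs from compound 2 by 4-methoxyphenyl in place of butyl on a carbonyl carbon. Going by the values given here, only the step from compound 1 to compound 2 bears on this: it altered the chain on the same carbonyl carbon without a step beyond the scatter. Nothing measured speaks to an aromatic group there, so no step beyond the scatter is expected: a 1.0-fold lower number from compound 2 to compound 3 (0.02 log units; within the scatter). Compound 3 is therefore estimated at 5000 nM, between 1500 nM and 16000 nM.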

Compound 3, half-maximal inhibitory concentration: 3500 nM
Estimate against measurement, compound 3: 1.4-fold (0.15 log units) above, within the range that was stated.
By their numbers in this assay, from the lowest: compounds 3, 2 and 1 (each within the scatter of the next).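

In this assay, going by these compounds alone, an aromatic group on this carbonyl carbon can now be read for the first time: 4-methoxyphenyl in place of butyl gives a 1.5-fold lower number from compound 2 to compound 3 (0.17 log units; within the scatter), and 4-methoxyphenyl in place of methyl gives a 2.0-fold lower number from compound 1 to compound 3 (0.29 log units; within the scatter). Methyl, butyl and 4-methoxyphenyl at this place are therefore not told apart by this read-out, ring or no ring. Nothing at hand accounts for this result. Still open, going by these compounds, is whether an amine, a carboxylic acid or a much longer chain on this carbonyl carbon would give a step beyond the scatter. Also open, on these data alone, is whether an unsubstituted phenyl would match 4-methoxyphenyl.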